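Changing the Five-Membered Ring on the Shared Core

This account rests on a few compounds, and the source may have more. Where it says the series, first, only, none or still open, it means among the compounds named here.

Compound 1 `c1csc(-c2ccccc2NCC2=NCCN2)c1` in a functional assay for activation of Alpha-1B adrenergic receptor (Homo sapiens), read by calcium flux (a higher number here means that more compound is needed for the effect, a lower number that less compound is needed), gives 5.75 nM.
Compound 2 `Cc1nc(-c2ccccc2NCC2=NCCN2)co1` in this assay gives < 5020 nM, which is a limit of the assay and not a number.
Compound 3 `c1ccc(-c2cnoc2)c(NCC2=NCCN2)c1` in this assay gives < 100000 nM, again only a limit.

Compound 3 therefore stands nowhere definite on the numbers shown: its result is a limit, and of the other two values one more is a limit, so only compound 1 carries a measured potency. Compound 4 `Cc1noc(-c2ccccc2NCC2=NCCN2)n1` differs from compound 3 by 3-methyl-1,2,4-oxadiazol-5-yl in place of 1,2-oxazol-4-yl on an aromatic carbon.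

The measured steps that touch this position all run into limits. The step that the limit leaves unreadable from compound 1 to compound 3 cannot be sized because of the limit of < 100000 nM in this assay, at which 1 of the 3 values shown sits, and the step that the two limits leave unreadable from compound 2 to compound 3 cannot be sized because of the limit of < 5020 nM in this assay, at which 1 of the 3 values shown sits, together with the limit of < 100000 nM in this assay, at which 1 of the 3 values shown sits. The step that the limit leaves unreadable from compound 1 to compound 2 is likewise unreadable. Among the compounds with values here, no measured step thus gives a size or a direction for exchanging one small aromatic ring for another here, and the expectation for compound 4 rests only on the fact that compound 1 is potent and that the two limits are not contradicted by any number.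

On that thin footing, compound 4 is estimated to give 500 nM in this assay, within a wide range from 20 nM to 20000 nM. Relative to compound 3 this estimate means an expected step that the limit leaves unreadable from compound 3 to compound 4, which cannot be checked against its limit.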

Compound 4, half-maximal effective concentration: < 5020 nM
Compound 4 gave a limit, no number; the forecaster's own chance of this, stated with the estimate: 30%; the middle value lies beyond the limit too.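

Within the data shown here, the result for compound 4 is a limit of the assay and not a number, and no step linking it to compound 1, compound 2 or compound 3 can be read. The compounds shown leave open how large any of these ring exchanges on the shared core is in this assay, and how compound 2, compound 3 and compound 4 rank against one another.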